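A Fluoro-for-Methyl Swap and Its Expected Effect

The compounds below may be only part of what the source reports. "The series", "measured", "known", "first", "only" and "open" are said of these compounds alone.

Compound 1 `Cc1ccc(C(=O)c2sc(Nc3ccccc3)c(C(=O)O)c2C)cc1`: 0.26% in a functional assay, with a stated time of 150 min, tested at 5 ug/mL; a lower number here means a weaker effect, a higher number a stronger effect of the compound at the concentration tested
Compound 2 `Cc1ccc(Nc2sc(C(=O)c3ccc(C)cc3)c(C)c2C(=O)O)cc1`: "not active" (no number reported) in this assay

Compound 1 gives 0.26% in this assay, a very weak effect. For compound 2 no single number is reported; in this assay compound 2 is recorded as "not active" (no number reported), so compound 2 stands without a value to set against compound 1. Compound 3 `Cc1ccc(C(=O)c2sc(Nc3ccc(F)cc3)c(C(=O)O)c2C)cc1` differs from compound 2 by fluoro in place of methyl on an aromatic carbon. Among the measured compounds shown here, no measured step of this kind exists, and no change beyond the scatter is expected in this assay. Compound 3 is therefore expected to give about 1%, within 0% to 10%.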

Compound 3, a percentage reported as activity, at one concentration (the size of the read-out at that concentration, not a potency): "not active" (no number reported)
No number was reported for compound 3; the estimate stays without a comparison.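

Among the compounds shown here, with no number for compound 2 or compound 3 in this assay, no step between them can be read, and no supporting evidence bears on this result. The compounds shown leave open whether fluoro in place of methyl changes the effect at all.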